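Diethylamino to Diisopropylamino on a Shared Core

The compounds below may be only part of what the source reports. "The series", "measured", "known", "first", "only" and "open" are said of these compounds alone.

In a functional assay on Caco-2 cells (Homo sapiens) for inhibition, read by MTT assay, with a stated time of 48 h, tested at 10 uM (on this read-out lower numbers stand for less inhibition of growth and higher numbers for more inhibition of growth at the one concentration tested), compound 1 (`CCN(CC)Cc1c(O)c([C@H]2CCN(C)C[C@H]2O)c2oc(C)cc(=O)c2c1O`) gives 17%. Compound 2 (`Cc1cc(=O)c2c(O)c(CN3CCN(C(=O)OC(C)(C)C)CC3)c(O)c([C@H]3CCN(C)C[C@H]3O)c2o1`) gives 21%. Within the data shown here, these two numbers lie within the usual scatter of each other, so compound 1 cannot be ranked against the only other measured compound. Among the measured compounds shown here, the two also differ in more than one place, and no measured pair isolates a single change.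

Compound 3 (`Cc1cc(=O)c2c(O)c(CN(C(C)C)C(C)C)c(O)c([C@H]3CCN(C)C[C@H]3O)c2o1`) has not yet been measured. It carries diisopropylamino in place of diethylamino on a saturated chain carbon bound to an aromatic carbon, and the rest of the structure is shared with compound 1: diisopropylamino in place of diethylamino on a saturated chain carbon bound to an aromatic carbon.

For the measured compounds named here, the data offer no direct precedent for this swap. The one indication is indirect: with a different group on that chain carbon, compound 2 gives 21%, within the scatter of compound 1. In this assay, the expected result is therefore no change beyond the scatter, with an estimated step of a number 3 percentage points higher from compound 1 to compound 3 (within the scatter). Compound 3 is expected to give 20%, within an estimated range from 8% to 35%.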

Compound 3, percent growth inhibition at one concentration: 22%
Compound 3: middle estimate off by 2 percentage points, on the low side, within the range that was stated.
By their numbers in this assay, from the lowest: compounds 1, 2 and 3 (each within the scatter of the next).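

Diisopropylamino in place of diethylamino on a saturated chain carbon bound to an aromatic carbon gives in this assay a step of a number 5 percentage points higher from compound 1 to compound 3 (within the scatter) and this is the first step among the compounds shown that isolates a single change. At this position, a group of 7 heavy atoms in place of one of 5, with the same count of hydrogen-bond donors and acceptors, therefore leaves no difference that can be read at the one concentration tested. No evidence is available that bears on this result.

The compounds shown leave open whether a ring amine such as morpholine or pyrrolidine, or a primary amine, on this chain carbon would give a step beyond the scatter from diethylamino in this assay. They also leave open whether a carboxylic acid on the same chain carbon, in place of any amine, would read differently on the shared core.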